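The compounds below may be only part of what the source reports. "The series", "measured", "known", "first", "only" and "open" are said of these compounds alone.

Working notes on the series. In an assay on isolated protein for inhibition of Amine oxidase [flavin-containing] A (Homo sapiens) (on this read-out higher numbers stand for weaker inhibition and lower numbers for stronger inhibition), compound 1 `CCN(CCCCCCOc1ccc(C(=O)/C=C/c2ccc(N(C)C)cc2)c(O)c1)Cc1ccccc1N(C)C` gives 37800 nM and compound 2 `CCN(CCCCCCOc1ccc(C(=O)/C=C/c2ccc(N(C)C)cc2)c(O)c1)Cc1ccc(N(C)C)cc1` gives 53600 nM. The single step between them, a 1.4-fold higher number from compound 1 to compound 2 (0.15 log units; within the scatter), keeps compound 2 within the scatter of compound 1, so on the two numbers shown compound 2 is not set apart. Compound 3 `CCN(CCCCCCOc1ccc(C(=O)/C=C/c2ccc(N(C)C)cc2)c(O)c1)Cc1ccccc1` differs from compound 2 by hydrogen in place of dimethylamino on an aromatic carbon. No measured step removes this group; the one step shown only relocates it and stays within the scatter, so no step beyond the scatter is expected here either. Compound 3 is expected at 50000 nM, in the range 20000 nM to 130000 nM, an estimated step of a 1.1-fold lower number from compound 2 to compound 3 (0.03 log units; within the scatter).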

Compound 3, half-maximal inhibitory concentration: 31600 nM
Estimate against measurement, compound 3: 1.6-fold (0.20 log units) above, within the range that was stated.
By their numbers in this assay, from the lowest: compounds 3, 1 and 2 (each within the scatter of the next).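

In this assay, hydrogen in place of dimethylamino gives a 1.7-fold lower number from compound 2 to compound 3 (0.23 log units; within the scatter) and a 1.2-fold lower number from compound 1 to compound 3 (0.08 log units; within the scatter) as the steps, so the group can leave this ring altogether, not only change place, without a step beyond the scatter. On these numbers, the series shows no dependence on dimethylamino at either location it occupies in compound 1 and compound 2. No evidence at hand bears on this result.

Still open, on these data alone, is whether a carboxylic acid or a nitrile on this ring would give a step beyond the scatter. A longer chain on the amine nitrogen is equally untested here.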